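Trifluoromethyl Added to Compound 4: An Expectation

The source may report more compounds than this note shows. Statements on the series, on what has been measured and on what is new or still open speak of the compounds shown alone.

Compound 1 `[O-]/[N+](=C\c1cn(-c2ccccc2)nn1)c1ccccc1` gives, in a functional assay on PC-3 cells (Homo sapiens) for inhibition, read by MTT assay, with a stated time of 24 h (on this read-out higher numbers stand for weaker inhibition and lower numbers for stronger inhibition), a value at the limit of > 100000 nM, which is a limit and not a number.
Compound 2 `[O-]/[N+](=C\c1cn(-c2ccc(F)cc2)nn1)c1ccccc1` gives in this assay 11400 nM.
Compound 3 `CC(C)(C)/[N+]([O-])=C/c1cn(-c2ccccc2)nn1` gives in this assay 15400 nM.

Among these, compound 3 and compound 2 sit close together, their numbers lying within the usual scatter of each other, while compound 1 sits at a limit (the limit of > 100000 nM in this assay, at which 1 of the 3 values shown sits). Compound 4 `CC(C)(C)/[N+]([O-])=C/c1cn(-c2ccc(C(F)(F)F)cc2)nn1` differs from compound 3 by one change: trifluoromethyl in place of hydrogen on an aromatic carbon.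

One measured step speaks to this change. Putting fluoro on that same ring gave an at least 8.7-fold lower number from compound 1 to compound 2 (0.94 log units; beyond the scatter), a step beyond the scatter toward stronger inhibition. The other step, an at least 6.4-fold lower number from compound 1 to compound 3 (0.81 log units; beyond the scatter), concerns the group on the nitrogen and bears only indirectly. A substituent on this ring has so far lowered the number, so compound 4 is expected to show a modest step toward stronger inhibition, a 3.4-fold lower number from compound 3 to compound 4 (0.53 log units; beyond the scatter). Compound 4 is therefore estimated at 4500 nM, with a plausible range from 1200 nM to 18000 nM.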

Compound 4, half-maximal inhibitory concentration: 42000 nM
Compound 4: the middle estimate sits 9.3-fold (0.97 log units) below what was measured, and the stated range ends below it.
By their numbers in this assay, from the lowest: compounds 2 and 3 (each within the scatter of the next); then compound 4. At a limit, above all of these: compound 1.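

Here the new group moved the number the other way: placing trifluoromethyl on the aromatic ring, para to a large group, gave a 2.7-fold higher number from compound 3 to compound 4 (0.44 log units; beyond the scatter) in this assay, so that substitution on this ring does not always go with stronger inhibition. The earlier fluoro step, an at least 8.7-fold lower number from compound 1 to compound 2 (0.94 log units; beyond the scatter), pointed toward stronger inhibition, but it was read on a core carrying phenyl on the nitrogen, whereas trifluoromethyl was read on a core carrying tert-butyl there, so the two steps differ in both the added group and its surroundings. Nothing measured here gives a reason for the direction of the new step.

The compounds shown leave open whether the change of group or the change of core decides the direction, since trifluoromethyl on the core of compound 1 and fluoro on the core of compound 3 do not appear among them. They also leave open how an amine, a carboxylic acid or a methoxy group would behave at this same position on the core of compound 3.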